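The source may hold more compounds than are shown below. What is called first, only, known or untested is meant among the compounds shown, and "the series" means these compounds.

Compound 1 `O=C1N(CCCCCCOc2ccc(C(F)(F)F)cc2)CCN1c1ccncc1`; compound 2 `O=C1N(CCCCCOc2ccc(C(F)(F)F)cc2)CCN1c1ccncc1`.

In a functional assay on cells (Homo sapiens) for cytotoxicity (on this read-out higher numbers stand for lower toxicity in this test and lower numbers for higher toxicity in this test), compound 1 gives > 25000 nM, which is a limit of the assay and not a number. In this assay compound 2 gives 12500 nM. For the measured compounds named here, for these two, only their values are known, with no step between them; compound 1 stands at the limit of > 25000 nM in this assay, at which 1 of the 2 values shown sits. Compound 3 `O=C1N(CCCCCCOc2ccc(Cl)cc2)CCN1c1ccncc1` differs from compound 1 in one place: chloro in place of trifluoromethyl on an aromatic carbon. Going by the values given here, no measured step of this kind is available, so in this assay the expected size of the step is none beyond the scatter, in no set direction, and the result for compound 3 is expected to sit at the same limit as often as not. Compound 3 is accordingly estimated at 25000 nM, within 10000 nM to 60000 nM. The implied step a number no higher from compound 1 to compound 3 (the limit leaves the size open) is expected to remain within the scatter.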

Compound 3, half-maximal cytotoxic concentration: > 25000 nM
Compound 3: only a limit was reported (the forecaster's own chance of this, stated with the estimate: 55%); the middle value lies on the limit itself.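

Compound 1 and compound 3 both stop at a limit of this assay and not at a number, so no step can be read between them: the limit of > 25000 nM in this assay, at which 2 of the 3 values shown sit. The compounds shown leave open whether chloro in place of trifluoromethyl on an aromatic carbon shifts the half-maximal cytotoxic concentration at all.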